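Replacing the hydroxy group of compound 3 with hydrogen

The source may report more compounds than this note shows. Statements on the series, on what has been measured and on what is new or still open speak of the compounds shown alone.

Compound 1 `c1ccc(-c2nnc(SCCCN3CCN(c4nc5ccccc5o4)CC3)o2)cc1` gives 57600 nM
Compound 2 `O=[N+]([O-])c1ccc(-c2nnc(SCCCN3CCN(c4nc5ccccc5s4)CC3)o2)cc1` gives 46500 nM
Compound 3 `Oc1ccc(-c2nnc(SCCCN3CCN(c4nc5ccccc5s4)CC3)o2)cc1` gives 54700 nM

All three values come from a functional assay on A-431 cells (Homo sapiens) for inhibition, read by MTT assay, with a stated time of 72 h (a lower number here means a stronger inhibitor, a higher number a weaker inhibitor), and lie within the scatter of one another. Compound 3, at 54700 nM here, therefore stands level with compound 1 and compound 2, and no order can be read among the three.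

The next compound is compound 4 `c1ccc(-c2nnc(SCCCN3CCN(c4nc5ccccc5s4)CC3)o2)cc1` and the change is hydrogen in place of hydroxy on an aromatic carbon in the step from 4-hydroxyphenyl to phenyl. Within the data shown here, no measured step covers hydrogen in place of hydroxy directly. The closest evidence is hydroxy in place of nitro on an aromatic carbon, which gave a 1.2-fold higher number from compound 2 to compound 3 (0.07 log units; within the scatter) in this assay and so left the value unmoved beyond the scatter. Compound 1 already carries phenyl but differs elsewhere in the core, and its 57600 nM sits in the same range.

On the strength of these small differences, no shift beyond the scatter is expected. The estimated step is a 1.1-fold lower number from compound 3 to compound 4 (0.04 log units; within the scatter) and is expected to stay within the scatter. For compound 4 the estimate is 50000 nM with an expected range of 27000 nM to 90000 nM in this assay.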

Compound 4, half-maximal inhibitory concentration: 93400 nM
Estimate against measurement, compound 4: 1.9-fold (0.27 log units) below; the whole stated range lies below it.
By their numbers in this assay, from the lowest: compounds 2, 3, 1 and 4 (each within the scatter of the next).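

In this assay, hydrogen in place of hydroxy on an aromatic carbon, para to a large group, gives a 1.7-fold higher number from compound 3 to compound 4 (0.23 log units; within the scatter) and hydrogen in place of nitro at the same place gives a 2.0-fold higher number from compound 2 to compound 4 (0.30 log units; within the scatter) so that compound 4 now supplies the unsubstituted phenyl partner for both substituted compounds, and neither step leaves the scatter. Among these compounds, the group on the amine nitrogen of the ring can also be read on its own for the first time, since 1,3-benzothiazol-2-yl in place of 1,3-benzoxazol-2-yl gives a 1.6-fold higher number from compound 1 to compound 4 (0.21 log units; within the scatter) and this step too stays within the scatter. No supporting measurement bears on these results, so they can be reported but not explained.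

The compounds shown leave open whether an amine, a carboxylic acid or a fluorine atom at this place on the aromatic ring, or a longer chain in the linker, would move the number beyond the scatter. Also open, on these data alone, is whether 1,3-benzoxazol-2-yl and 1,3-benzothiazol-2-yl would remain within the scatter of each other when the aromatic ring carries hydroxy or nitro.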